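This account rests on a few compounds, and the source may have more. Where it says the series, first, only, none or still open, it means among the compounds named here.

In a functional assay on HOS cells (Homo sapiens) for inhibition, with a stated time of 72 h (on this read-out lower numbers stand for stronger inhibition and higher numbers for weaker inhibition), three compounds that share one core differ only in a single substituent on an aromatic carbon. Compound 1 `NC1CCC(Nc2nc(NCc3ccc(Br)cc3)c3ncn(C4CCCC4)c3n2)CC1`, which carries bromo, gives 995 nM. Compound 2 `NC1CCC(Nc2nc(NCc3ccc(-c4cccc(F)c4)cc3)c3ncn(C4CCCC4)c3n2)CC1`, with 3-fluorophenyl at that place, gives 211 nM. Compound 3 `NC1CCC(Nc2nc(NCc3ccc(-n4cccn4)cc3)c3ncn(C4CCCC4)c3n2)CC1`, with 1H-pyrazol-1-yl there, gives 103 nM, the lowest number of the three.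

Compound 4 `NC1CCC(Nc2nc(NCc3ccc(-c4cccs4)nc3)c3ncn(C4CCCC4)c3n2)CC1` has yet to be measured. It keeps the shared core, and the change is 6-(thiophen-2-yl)pyridin-3-yl in place of 4-(1H-pyrazol-1-yl)phenyl on a saturated chain carbon bound to a nitrogen on an aromatic ring.

Replacing bromo gave the two larger steps, a 4.7-fold lower number from compound 1 to compound 2 (0.67 log units; beyond the scatter) and a 9.7-fold lower number from compound 1 to compound 3 (0.98 log units; beyond the scatter), but compound 4 involves no such replacement. Within the data shown here, the closest precedent is the exchange of one ring substituent for another, a 2.0-fold lower number from compound 2 to compound 3 (0.31 log units; beyond the scatter), which only just clears the scatter. Among the measured compounds shown here, no measured compound contains a thiophene or a pyridine, so the data offer no direct guide to either ring. For the measured compounds named here, no step beyond the scatter is therefore expected, only a slight lean towards a higher number, since compound 3 holds the lowest value so far. The expected step is a 1.5-fold higher number from compound 3 to compound 4 (0.16 log units; within the scatter). For compound 4 the estimated value is 150 nM, with an expected range from 50 nM to 450 nM.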

Compound 4, half-maximal inhibitory concentration: 32 nM
For compound 4 the middle estimate is 4.7-fold (0.67 log units) above the measured one; measured number outside the range, below it.
By their numbers in this assay, from the lowest: compound 4; then compound 3; then compound 2; then compound 1.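

In this assay, among these compounds, the exchange of 4-(1H-pyrazol-1-yl)phenyl for 6-(thiophen-2-yl)pyridin-3-yl on a saturated chain carbon bound to a nitrogen on an aromatic ring gives a 3.2-fold lower number from compound 3 to compound 4 (0.51 log units; beyond the scatter) and shows that this position can still yield a lower number than the best of the earlier compounds. Both rings change in this step, yet the heavy-atom count and the hydrogen-bond donor and acceptor counts stay the same, so the gain comes with a different set of ring atoms and no added size. Among the compounds shown here, measured against the 4-bromophenyl group, the change amounts to a 31-fold lower number from compound 1 to compound 4 (1.49 log units; beyond the scatter) and is the only step of large size in this set, though no measurement at hand accounts for it.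

The compounds shown leave open whether the pyridine, the thiophene or the pairing of the two carries the step, a question that 4-(thiophen-2-yl)phenyl and 6-(1H-pyrazol-1-yl)pyridin-3-yl would separate. Also open, from the compounds shown here alone, is how an amine or a carboxylic acid in place of the thiophene would read in this assay at this position.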